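Swapping a dichlorophenyl for a methoxyphenyl on the ketone

The source may hold more compounds than are shown below. What is called first, only, known or untested is meant among the compounds shown, and "the series" means these compounds.

Of the compounds shown here, three have been tested in an ADME assay on L929 cells (Mus musculus) for cytotoxicity, read by resazurin assay, with a stated time of 72 h; on this read-out higher numbers stand for weaker inhibition and lower numbers for stronger inhibition. Compound 1 `OB1OCc2ccc(-n3cc(Sc4ccc(O)cc4)c4ccccc43)cc21` gives > 10 ug/mL, which is a limit of the assay rather than a number. Compound 2 `OB1OCc2ccc(-n3cccc3Sc3ccc(Cl)cc3)cc21` likewise reaches only a limit, > 10 ug/mL. Compound 3 `O=C(c1ccn(-c2ccc3c(c2)B(O)OC3)c1)c1ccc(Cl)cc1Cl` also stands at a limit, > 10 ug/mL, so the numbers shown do not separate it from the other two. All three sit at the limit of > 10 ug/mL in this assay, at which 3 of the 3 values shown sit. Compound 4 `COc1ccccc1C(=O)c1ccn(-c2ccc3c(c2)B(O)OC3)c1` differs from compound 3 in one place, (2-methoxyphenyl in place of 2,4-dichlorophenyl on a carbonyl carbon). For the measured compounds named here, no measured pair shows a change of this kind, so no step beyond the scatter is expected in this assay. Compound 4 is therefore expected to give 10 ug/mL, in a range from 5 ug/mL to 20 ug/mL. The step this estimate implies, a number no higher from compound 3 to compound 4 (the limit leaves the size open), is expected to be no more than the scatter.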

Compound 4, half-maximal inhibitory concentration: > 10 ug/mL
Compound 4: no number, only a limit; the forecaster's own chance of this, stated with the estimate: 80%; the middle value sits exactly at the limit.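

Compound 3 and compound 4 both stand at a limit, so no step can be read between them: the limit of > 10 ug/mL in this assay, at which 4 of the 4 values shown sit.

The compounds shown leave open whether 2-methoxyphenyl and 2,4-dichlorophenyl on the carbonyl carbon differ at all in their effect on the read-out.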